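Aminomethyl in place of pyrrolidin-2-yl on a carbonyl carbon

A few compounds are considered here, and "the series" means these few. Any claim that something is new, unique, unknown or untested is made for them only; others in the source may bear on it.

Compound 1 (`C=C1CC[C@H]2[C@@](C)(CC[C@@H](O)[C@@]2(C)NC=O)[C@@H]1/C=C/C1=CCOC1=O`): > 50000 nM (a limit)
Compound 2 (`C=C1CC[C@H]2[C@@](C)(CC[C@@H](OC(=O)[C@H]3CCCN3)[C@@]2(C)NC=O)[C@@H]1/C=C/C1=CCOC1=O`): > 50000 nM (a limit)

In a functional assay on RAW264.7 cells (Mus musculus) for inhibition, read by Griess assay, with stated times of 3 h and 24 h (a higher number here means a weaker inhibitor, a lower number a stronger inhibitor), compound 2 gives > 50000 nM as a limit of the assay, not a number. Compound 1 gives > 50000 nM as a limit too. Together they show the limit of > 50000 nM in this assay, at which 2 of the 2 values shown sit, and nothing firmer. The change to compound 3 (`C=C1CC[C@H]2[C@@](C)(CC[C@@H](OC(=O)CN)[C@@]2(C)NC=O)[C@@H]1/C=C/C1=CCOC1=O`) is aminomethyl in place of pyrrolidin-2-yl on a carbonyl carbon on a carbonyl carbon, with aminomethyl in place of pyrrolidin-2-yl. Going by the values given here, the one measured step that bears on it is a step that the two limits leave unreadable from compound 1 to compound 2 and offers no size to carry over. Since compound 2 rests at > 50000 nM as a limit, no step beyond the scatter is expected in this assay here. The expected step is a number no higher from compound 2 to compound 3 (the limit leaves the size open) by this estimate. Compound 3 is expected to stay at or near that limit, at an estimated 50000 nM within an expected range of 20000 nM to 100000 nM overall.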

Compound 3, half-maximal inhibitory concentration: > 50000 nM
Compound 3: only a limit was reported; the forecaster's own chance of this, stated with the estimate: 80%; the middle value lies on the limit itself.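

No step from compound 1 or compound 2 to compound 3 can be read, since all three compounds rest at one limit: the limit of > 50000 nM in this assay, at which 3 of the 3 values shown sit.

Going by these compounds, how strongly compound 1, compound 2 and compound 3 inhibit, and whether aminomethyl and pyrrolidin-2-yl differ on the carbonyl carbon, stays open.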